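This account rests on a few compounds, and the source may have more. Where it says the series, first, only, none or still open, it means among the compounds named here.

Compound 3 `N#CC1=C(N)OC(c2c[nH]c3ccccc23)=C(C#N)C1c1ccccc1F` belongs to a small set of analogues built on one shared core, and in a functional assay, tested at 200 ug/mL (a lower number here means a weaker effect, a higher number a stronger effect of the compound at the concentration tested), compound 3 is recorded as "not active" (no number reported). In this assay compound 1 `N#CC1=C(N)OC(c2c[nH]c3ccccc23)=C(C#N)C1c1ccc(F)cc1` gives 22.4%, and compound 2 `CN(C)c1ccc(C2C(C#N)=C(N)OC(c3c[nH]c4ccccc34)=C2C#N)cc1` gives 20.5%; the step of a number 1.9 percentage points lower from compound 1 to compound 2 (within the scatter) shows that the exchange of dimethylamino for fluoro on an aromatic carbon leaves the read-out essentially unchanged. For compound 3 the study reports no number at all in this assay, only that it showed no activity, so its standing cannot be placed on the same scale as compound 1 and compound 2.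

The step to compound 4 `N#CC1=C(N)OC(c2c[nH]c3ccccc23)=C(C#N)C1c1ccc(Br)cc1` is 4-bromophenyl in place of 2-fluorophenyl on a saturated ring carbon. Within the data shown here, no measured step matches this change directly: the one step available, from compound 1 to compound 2, concerns the substituent on the aromatic ring and not a move of the substituent to a different carbon of that ring, so it bears on the question only loosely. Compound 4 carries its bromine in the same arrangement as the fluorine of compound 1, and compound 1 and compound 2 both sit near the low end of this assay. Compound 4 is therefore expected to give about 20%, with a plausible range of 6% to 34%, and it remains possible that the assay again reports no number, as it did for compound 3.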

Compound 4, a percentage reported as activity, at one concentration (the size of the read-out at that concentration, not a potency): 10.6%
Estimate against measurement, compound 4: 9.4 percentage points above; the measured number falls inside the stated range.
By their numbers in this assay, from the lowest: compounds 4, 2 and 1 (each within the scatter of the next, the first and the last beyond it).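

Among these compounds, in (this assay), the 4-bromophenyl group on the saturated ring carbon still gives a number, and the exchange of bromo for fluoro shows that the group on this aromatic carbon can move the read-out (a number 11.8 percentage points lower from compound 1 to compound 4 (beyond the scatter)), which the one earlier step, staying within the scatter, did not show. The exchange of bromo for dimethylamino gives a smaller step (a number 9.9 percentage points lower from compound 2 to compound 4 (within the scatter)), so these two groups cannot be told apart here. The step from compound 3 cannot be read, as compound 3 has no number, and nothing shown accounts for these differences.

As far as these compounds go, it stays open whether a chloro, a methoxy or a carboxylic acid on that same aromatic carbon would read like bromo or like fluoro. From the compounds shown here alone, how these compounds compare at other concentrations also stays open.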